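A few compounds are considered here, and "the series" means these few. Any claim that something is new, unique, unknown or untested is made for them only; others in the source may bear on it.

Three compounds with a shared amide linking two ring systems have been tested, and a fourth awaits its number. Compound 1 `COc1ccc(-c2ccc(C(=O)Nc3ccc(Oc4ccnc5[nH]ccc45)c(F)c3)nc2)cc1` carries a methoxy group on its outer ring; in a functional assay on A549 cells (Homo sapiens) for cytotoxicity, read by MTT assay, with a stated time of 72 h (a lower number here means a stronger inhibitor, a higher number a weaker inhibitor), compound 1 gives 2240 nM. Compound 2 `O=C(Nc1ccc(Oc2ccnc3[nH]ccc23)c(F)c1)c1ccc(-c2ccc(F)cc2)cn1` is the same molecule with one change: fluoro in place of methoxy on an aromatic carbon. That change produced a 2.7-fold higher number from compound 1 to compound 2 (0.43 log units; beyond the scatter), so compound 2 gives 6010 nM in this assay. Compound 3 `COc1ccc(-c2ccnc(C(=O)Nc3ccc(Oc4ccnc5[nH]ccc45)c(F)c3)c2)cc1` keeps the methoxy group but has a different core from compound 1; how the two cores differ is not broken down here. In this assay compound 3 gives 1040 nM, the lowest of the three numbers.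

Compound 4 `O=C(Nc1ccc(Oc2ccnc3[nH]ccc23)c(F)c1)c1cc(-c2ccc(F)cc2)ccn1` has not yet been measured. It differs from compound 3 in one place: fluoro in place of methoxy on an aromatic carbon. This is the same change already seen between compound 1 and compound 2, and the spot it occupies is described in the same words in both pairs. The expectation for compound 4 therefore rests on compound 3 and on how the change behaved once before: the number is expected to rise by about a 2.7-fold higher number from compound 3 to compound 4 (0.43 log units; beyond the scatter) in this assay, because a matching rise was measured as a 2.7-fold higher number from compound 1 to compound 2 (0.43 log units; beyond the scatter). Going by the values given here, on that basis compound 4 is estimated at 2800 nM in this assay, with a likely range from 1300 nM to 6000 nM, since only one earlier example of this change is available and the two cores are not the same.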

Compound 4, half-maximal inhibitory concentration: 1090 nM
Estimate against measurement, compound 4: 2.6-fold (0.41 log units) above; measured number below the stated range.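

On the core of compound 3, fluoro in place of methoxy on an aromatic carbon gives a 1.0-fold higher number from compound 3 to compound 4 (0.02 log units; within the scatter) in this assay, so compound 3 and compound 4 cannot be told apart in this measurement. Set beside the earlier step on the core of compound 1, the new step does not differ from it by more than repeated measurements could: the same change on two cores in this assay, a 2.7-fold higher number (0.43 log units; beyond the scatter) from compound 1 to compound 2 and a 1.0-fold higher number (0.02 log units; within the scatter) from compound 3 to compound 4, 2.6-fold (0.41 log units) apart, within the scatter of two such steps This does not show that the core alters what the change does, and it does not show that the change carries over unaltered either, since with a single pair on each core, a true difference between the cores and ordinary scatter cannot be separated.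

On these data alone, both pairs compare only methoxy and fluoro, so it remains open how either core would respond to a different group at that spot, such as an amine, a carboxylic acid or a longer chain. As far as these compounds go, it also remains open whether the step would settle nearer one result or the other with further pairs, for example the same two groups on a third core.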